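Replacing phenyl with (1H-pyrazol-1-yl)methyl in compound 2

The source may hold more compounds than are shown below. What is called first, only, known or untested is meant among the compounds shown, and "the series" means these compounds.

Measured in a functional assay on a cell-free system (plasma, Homo sapiens), with a stated time of 3 min; a higher number here means a weaker inhibitor, a lower number a stronger inhibitor:
Compound 1 `O=C(NCc1cc(Cl)ccc1-n1cnnn1)[C@@H]1C[C@@H]2C[C@@H]2N1C(=O)[C@H](O)c1cccc(Cl)c1`: 1000 nM
Compound 2 `O=C(NCc1cc(Cl)ccc1-n1cnnn1)[C@@H]1[C@H]2C[C@H]2CN1C(=O)[C@H](O)c1ccccc1`: 960 nM

Compound 2, at 960 nM, stands level with compound 1 at 1000 nM, as the two values lie within the usual scatter of each other. Among the measured compounds shown here, these two compounds differ in more than one place, so they offer no single-change step to draw on.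

Compound 3 `O=C(NCc1cc(Cl)ccc1-n1cnnn1)[C@@H]1[C@H]2C[C@H]2CN1C(=O)[C@H](O)Cn1cccn1` carries (1H-pyrazol-1-yl)methyl in place of phenyl on a saturated chain carbon bound to a carbonyl carbon and an oxygen on a saturated carbon. For the measured compounds named here, with no measured step to guide it, the expectation rests on this structural change alone and points to a moderately higher number, meaning a weaker inhibitor. The expected change is a 3.1-fold higher number from compound 2 to compound 3 (0.49 log units; beyond the scatter). For compound 3 the estimated value is 3000 nM, with an expected range of 800 nM to 12000 nM.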

Compound 3, half-maximal inhibitory concentration: 1800 nM
Beside the measured number, compound 3's estimate is 1.7-fold (0.22 log units) above it, within the range that was stated.
By their numbers in this assay, from the lowest: compounds 2, 1 and 3 (each within the scatter of the next).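

In this assay, the exchange of phenyl for (1H-pyrazol-1-yl)methyl on a saturated chain carbon bound to a carbonyl carbon and an oxygen on a saturated carbon gives a 1.9-fold higher number from compound 2 to compound 3 (0.27 log units; within the scatter), the first single-change step available at this position. The position therefore tolerates a five-membered aromatic ring with 2 hetero atoms in place of a six-membered aromatic ring of carbon only, and the 2 hydrogen-bond acceptors that enter, at an equal count of heavy atoms, leave the step within the scatter. No measurement shown bears on the reason for this result.

As far as these compounds go, whether an amine, a carboxylic acid or a longer chain on this same carbon would also stay within the scatter of compound 2 remains open. Also open, from the compounds shown here alone, is whether (1H-pyrazol-1-yl)methyl would give a similar step on the core of compound 1.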